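The source may report more compounds than this note shows. Statements on the series, on what has been measured and on what is new or still open speak of the compounds shown alone.

Compound 1 `O=S(=O)(Nc1ccc(Cl)cc1)c1ccc2nc(-c3ccccc3)c(-c3ccccc3)nc2c1` gives 100% in an ADME assay on the whole organism for pharmacokinetics, with Homo sapiens as the target; a higher number here means that a larger share of the oral dose reaches the circulation, a lower number that a smaller share of the oral dose reaches the circulation. Compound 2 `O=S(=O)(Nc1ccccc1)c1ccc2nc(-c3ccccc3)c(-c3ccccc3)nc2c1` gives 100% in this assay; the step of no change at the digits printed from compound 1 to compound 2 (within the scatter) shows that removing the ring chloro leaves the read-out where it was. Compound 2 thus stands level with compound 1, both at the top of the range covered so far, so there is no spread in the series from which a trend could be read. Compound 3 `O=C(NS(=O)(=O)c1ccc2nc(-c3ccccc3)c(-c3ccccc3)nc2c1)c1ccccc1` is not yet measured; it differs from compound 2 by benzoyl in place of phenyl on a sulfonamide nitrogen. Among the compounds with values here, the only measured step concerns a substituent on a ring and not the sulfonamide nitrogen, so no measured step bears on this change, and the size of the step is not fixed by the data. A downward step of a number 30 percentage points lower from compound 2 to compound 3 (beyond the scatter) is expected on that basis. For compound 3 the expected value in this assay is 70%, with a range from 30% to 100%.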

Compound 3, oral bioavailability: 100%
Compound 3: the middle estimate sits 30 percentage points below what was measured, within the range that was stated.
By their numbers in this assay, from the lowest: compounds 1, 2 and 3 (each within the scatter of the next).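

On the sulfonamide nitrogen, benzoyl in place of phenyl gives no change at the digits printed from compound 2 to compound 3 (within the scatter) in this assay, the first read on this position, where the earlier pair spoke only to a chloro on an aromatic carbon. Benzoyl in place of 4-chlorophenyl at the same nitrogen gives no change at the digits printed from compound 1 to compound 3 (within the scatter), so neither change on this nitrogen, including the entry of a carbonyl, separates the compounds in this read-out. No supporting data bear on why the read-out holds across these changes.

Open, on these data alone, is whether a carboxylic acid, an amine or a longer chain on the sulfonamide nitrogen would separate from these compounds. With no spread among the three compounds, the series also leaves open which changes, at this position or on the shared core, would move the read-out at all.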